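The source may report more compounds than this note shows. Statements on the series, on what has been measured and on what is new or still open speak of the compounds shown alone.

In a functional assay on NCI-H460 cells (Homo sapiens) for cytotoxicity, read by MTT assay, with a stated time of 68 h (on this read-out higher numbers stand for weaker inhibition and lower numbers for stronger inhibition), compound 1 `O=C(Nc1cccc(-c2ccccc2Cl)c1)C(Cl)Cl` gives > 50000 nM, which is a limit of the assay and not a number. Compound 1 therefore stands at the limit of > 50000 nM in this assay, at which 1 of the 2 values shown sits, and nowhere more precise. Compound 2 `O=C(Nc1cc(-c2ccc(OC3CCCCO3)cc2)cc(-c2ccc(OC3CCCCO3)cc2)c1)C(Cl)Cl` gives 2420 nM in this assay. Among the measured compounds shown here, no pair of measured compounds differing in one place is available, so no measured step is known. Compound 3 `O=C(Nc1cccc(-c2ccccc2F)c1)C(Cl)Cl` differs from compound 1 by fluoro in place of chloro on an aromatic carbon. The expected step is a step that the limit leaves unreadable from compound 1 to compound 3, none beyond the scatter. Compound 3 is estimated at 60000 nM, within 20000 nM to 200000 nM, most likely again reported only as a limit.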

Compound 3, half-maximal inhibitory concentration: 26800 nM
Compound 3: the middle estimate sits 2.2-fold (0.35 log units) above what was measured, and the stated range covers the measured number.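

Fluoro in place of chloro on an aromatic carbon, ortho to a large group, gives an at least 1.8-fold lower number from compound 1 to compound 3 (0.27 log units; that floor lies within the scatter). Compound 3 therefore gives the core of compound 1 a readable number in this assay, which neither earlier compound could do for this position. The true size of the step remains unknown because compound 1 sits at a limit: the limit of > 50000 nM in this assay, at which 1 of the 3 values shown sits.

Going by these compounds, whether a methoxy group or an amine at this position would move the number further remains open. Compound 2 differs from this pair in more than one place, so it does not address this change.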